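Dropping one chloro from a dichlorinated purine-type growth inhibitor

A few compounds are considered here, and "the series" means these few. Any claim that something is new, unique, unknown or untested is made for them only; others in the source may bear on it.

Compound 1: `ClCc1ccc(Cn2cnc3c(Cl)ncnc32)cc1` — 3020 nM
Compound 2: `ClCc1ccccc1Cn1cnc2c(Cl)nc(Cl)nc21` — 1230 nM

In a functional assay on OVCAR-8 cells (Homo sapiens) for cytotoxicity, read by sulforhodamine B assay, with a stated time of 48 h (on this read-out higher numbers stand for weaker inhibition of growth and lower numbers for stronger inhibition of growth), compound 2 gives 1230 nM, the lower of the two numbers recorded so far. Compound 1 gives 3020 nM in this assay, a higher number that lies beyond the usual scatter, so compound 2 is the stronger growth inhibitor of the pair. Compound 3, `ClCc1ccccc1Cn1cnc2c(Cl)ncnc21`, is the next step: hydrogen in place of chloro on an aromatic carbon. Among the measured compounds shown here, no measured pair in this set shows this exact change, so the size of the step has to be estimated. Compound 1, which also carries a single chloro on its core, sits at a weaker level, and removing a group has more often weakened than strengthened inhibition in series of this kind. A modest loss of potency is expected, with the step from compound 2 to compound 3 estimated at a 2.0-fold higher number from compound 2 to compound 3 (0.31 log units; beyond the scatter). Compound 3 is therefore expected to give about 2500 nM, within a range of 1000 nM to 6500 nM.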

Compound 3, concentration for 50% growth inhibition: 2240 nM
Estimate against measurement, compound 3: 1.1-fold (0.05 log units) above, and the stated range covers the measured number.
By their numbers in this assay, from the lowest: compounds 2, 3 and 1 (each within the scatter of the next, the first and the last beyond it).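

In this assay, the chloro on the aromatic carbon between two ring nitrogen atoms can give way to hydrogen with only a 1.8-fold higher number from compound 2 to compound 3 (0.26 log units; within the scatter), so the two compounds cannot be told apart on this read-out. Among the compounds shown here, this is the first direct look at this position, and it shows that growth inhibition at this level does not depend on that chloro, at least while the rest of the molecule stays the same. This single pair leaves open whether a different group at the same carbon, such as an amine or a methoxy group, would shift the number beyond the scatter, and whether the remaining chloro and the chloromethyl group matter more. No further measurement is available to explain why this swap leaves the reading within the scatter.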